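This account rests on a few compounds, and the source may have more. Where it says the series, first, only, none or still open, it means among the compounds named here.

The series shares one core, carried by compound 1 `OC[C@H]1O[C@@H](n2cnc3c(CSc4ccccc4)ncnc32)[C@H](O)[C@@H]1O`, compound 2 `OC[C@H]1O[C@@H](n2cnc3c(CSc4ccccn4)ncnc32)[C@H](O)[C@@H]1O` and compound 3 `OCCSCc1ncnc2c1ncn2[C@@H]1O[C@H](CO)[C@@H](O)[C@H]1O`, which differ only in the group on a sulfur. In a functional assay on Huh-7 cells (Homo sapiens) for cytotoxicity, read by MTT assay, with a stated time of 3 days (a higher number here means that more compound is tolerated, a lower number that less compound is tolerated), compound 1 reaches only the limit of the assay, > 100000 nM. In this assay compound 2 likewise returns a limit, > 100000 nM. Compound 3 too stops at a limit in this assay, > 100000 nM. The change of pyridin-2-yl in place of phenyl on a sulfur gives a step that the two limits leave unreadable from compound 1 to compound 2, 2-hydroxyethyl in place of phenyl gives a step that the two limits leave unreadable from compound 1 to compound 3, and 2-hydroxyethyl in place of pyridin-2-yl gives a step that the two limits leave unreadable from compound 2 to compound 3. All three values sit at the limit of > 100000 nM in this assay, at which 3 of the 3 values shown sit, so compound 2 stands where every measured member stands, at a limit and not a number. Compound 4 `O=c1ccn(Cc2ncnc3c2ncn3[C@@H]2O[C@H](CO)[C@@H](O)[C@H]2O)cc1` is the next member, made from compound 2 by a group of 7 heavy atoms (5 carbon, 1 nitrogen, 1 oxygen; one six-membered aromatic ring with 1 hetero atom) in place of a group of 7 heavy atoms (5 carbon, 1 nitrogen, 1 sulfur; one six-membered aromatic ring with 1 hetero atom), on a saturated chain carbon bound to an aromatic carbon. For the measured compounds named here, none of the measured steps can be sized, and each replacement of the group on the sulfur has so far left the read-out at the limit, so no step beyond the scatter is expected for a step that the limit leaves unreadable from compound 2 to compound 4. Compound 4 is estimated at 150000 nM, within 60000 nM to 400000 nM, and is expected to be reported as a limit rather than a number.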

Compound 4, half-maximal cytotoxic concentration: > 100000 nM
Compound 4: a limit, no number (the forecaster's own chance of this, stated with the estimate: 80%); the middle value lies beyond the limit too.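

Compound 4 also stops at a limit in this assay, so none of its steps from compound 1, compound 2 or compound 3 can be read, and the series stays as it stood: the limit of > 100000 nM in this assay, at which 4 of the 4 values shown sit. The compounds shown leave open how these four rank among themselves and whether any group on the shared core would give a measurable number.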